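Swapping a Para Iodo for Methyl in a Weak Series

A few compounds are considered here, and "the series" means these few. Any claim that something is new, unique, unknown or untested is made for them only; others in the source may bear on it.

Compound 1 `Cc1nn(C)c(Oc2ccc(F)cc2F)c1/C=N\CCCCCCOc1cc2oc(=O)cc(C)c2cc1Cl` reaches only the limit of > 25000 nM in a functional assay on SMMC-7721 cells (Homo sapiens) for antiproliferative activity, read by MTT assay, with a stated time of 72 h (on this read-out higher numbers stand for weaker inhibition and lower numbers for stronger inhibition), which is a limit and not a number (the limit of > 25000 nM in this assay, at which 1 of the 3 values shown sits). Compound 2 `Cc1nn(C)c(Oc2ccccc2Br)c1/C=N\CCCCCCOc1cc2oc(=O)cc(C)c2cc1Cl` gives 19700 nM in this assay, and compound 3 `Cc1nn(C)c(Oc2ccc(I)cc2)c1/C=N\CCCCCCOc1cc2oc(=O)cc(C)c2cc1Cl` gives 13300 nM, the lowest of the two numbers shown, with compound 2 as its nearest neighbour. The changes on the phenoxy ring gave steps of an at least 1.2-fold lower number from compound 1 to compound 2 (0.10 log units; that floor lies within the scatter), an at least 1.8-fold lower number from compound 1 to compound 3 (0.27 log units; that floor lies within the scatter) and a 1.5-fold lower number from compound 2 to compound 3 (0.17 log units; within the scatter), none clearly beyond the scatter. Compound 4 `Cc1ccc(Oc2c(/C=N\CCCCCCOc3cc4oc(=O)cc(C)c4cc3Cl)c(C)nn2C)cc1` differs from compound 3 by methyl in place of iodo on an aromatic carbon. Since the earlier aryl changes moved this assay little, the step of a 1.4-fold higher number from compound 3 to compound 4 (0.13 log units; within the scatter) is expected to stay small. Compound 4 is therefore estimated at 18000 nM, within 9000 nM to 40000 nM.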

Compound 4, half-maximal inhibitory concentration: 18600 nM
Estimate against measurement, compound 4: 1.0-fold (0.01 log units) below; measured number inside the range.
By their numbers in this assay, from the lowest: compounds 3, 4 and 2 (each within the scatter of the next). At a limit, above all of these: compound 1.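

In this assay the change to methyl from iodo gives a 1.4-fold higher number from compound 3 to compound 4 (0.15 log units; within the scatter) and so shows that a group other than a halogen can sit at this place on the ring without a clear change. Against the 2-bromophenyl the picture is the same, with a 1.1-fold lower number from compound 2 to compound 4 (0.02 log units; within the scatter) for the 4-methylphenyl. Compound 1 is a limit, so an at least 1.3-fold lower number from compound 1 to compound 4 (0.12 log units; that floor lies within the scatter) gives only a floor: the limit of > 25000 nM in this assay, at which 1 of the 4 values shown sits.

As far as these compounds go, whether an amine, a carboxylic acid or a methoxy group at this place would lower the number beyond the scatter stays open. So does the effect of a shorter linking chain.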